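The compounds below may be only part of what the source reports. "The series", "measured", "known", "first", "only" and "open" are said of these compounds alone.

Measured compounds:
- compound 1, `Cc1cc2c(c(=O)[nH]1)OC(C(=O)CC(C)C)O2`; in a functional assay on TE-8 cells (Homo sapiens) for cytotoxicity, read by WST assay, with a stated time of 48 h (on this read-out higher numbers stand for weaker inhibition and lower numbers for stronger inhibition), compound 1 gives > 100000 nM
- compound 2, `CC1=CC(=O)[C@]2(O[C@@H]2C(=O)CC(C)C)C(=O)N1`; in this assay compound 2 gives "not determined" (no result reported)

The value for compound 1 is a limit of this assay and not a number; it sits at the limit of > 100000 nM in this assay, at which 1 of the 2 values shown sits. For compound 2 no number is available in this assay, so compound 2 stands nowhere on the scale shown: the only value with any content in the series is the limit of compound 1, and the two compounds differ in more than one place, so nothing can be read from the pair.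

Compound 3, `CC1=CC(=O)C2(OC2C(=O)CC(C)C)C(=O)N1`, is the unmeasured member. Against compound 2 the change is the two compounds have the same atoms and bonds; at least one stereo element is drawn with a configuration in one of them and without one in the other: 2 of 2 stereo elements differ; a stereocentre at a saturated ring carbon is drawn S in compound 2 and without a configuration in compound 3; a stereocentre at a saturated ring carbon is drawn S in compound 2 and without a configuration in compound 3. The atoms and bonds are identical; only the drawn configuration at the two saturated ring carbons is lost. No measured step is shown for any pair here, so no step size can be taken from the data. For this change alone, no step beyond the usual scatter is expected in this assay, though with compound 2 undetermined there is no anchor.

The estimate for compound 3 therefore rests on compound 1 alone: compound 3 is expected to give about 100000 nM in this assay, within 30000 nM to 300000 nM, with a real chance that only a limit is reported.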

Compound 3, half-maximal inhibitory concentration: 21600 nM
The estimate for compound 3 lay 4.6-fold (0.67 log units) above the measured number, and the stated range ends above it.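

No new step can be read for compounds 2 and 3: in this assay compound 3 gives 21600 nM, while the entry for compound 2 holds no number, and compound 1 differs from both in more than one place. Still open, from the compounds shown here alone, is whether the drawn configuration at the two saturated ring carbons matters on this read-out.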